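Swapping Fluoro for Methoxy on the Aryl Ring

This account rests on a few compounds, and the source may have more. Where it says the series, first, only, none or still open, it means among the compounds named here.

Three compounds sharing one core have been measured in a functional assay on CHO cells for agonist activity at adenosine receptor A1 (Homo sapiens), read by fluorescence and ERK phosphorylation, with stated times of 30 min and 1.5 h, tested at 3 uM; on this read-out lower numbers stand for a weaker effect and higher numbers for a stronger effect at the one concentration tested:

compound 1 `Nc1scc(-c2cccc(F)c2)c1C(=O)c1ccc(Cl)cc1` gives 76%
compound 2 `Nc1scc(-c2ccc(Cl)cc2)c1C(=O)c1ccc(Cl)cc1` gives 50%
compound 3 `Nc1scc(-c2ccc(Br)cc2)c1C(=O)c1ccc(Cl)cc1` gives 45%

Compound 1 stands highest of the three. The step of a number 26 percentage points lower from compound 1 to compound 2 (beyond the scatter) and the step of a number 31 percentage points lower from compound 1 to compound 3 (beyond the scatter) both go downward and beyond the scatter, while the step of a number 5 percentage points lower from compound 2 to compound 3 (within the scatter) stays within it, so compound 2 and compound 3 cannot be told apart.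

Compound 4 `COc1cccc(-c2csc(N)c2C(=O)c2ccc(Cl)cc2)c1` is not yet measured. It differs from compound 1 in one place: methoxy in place of fluoro on an aromatic carbon.

Among the compounds with values here, none of the measured steps makes this exact exchange. Within the data shown here, the two steps away from compound 1 change both the place of the group on the ring and its identity at once, so they show only that altering this ring can cost a fair amount of activity; the step between compound 2 and compound 3, which keeps the place and swaps one halogen for another, changes little. A methoxy kept at the place of the fluoro is therefore expected to cost a modest amount at most, with a real chance of no change beyond the scatter, which is what the expected step of a number 14 percentage points lower from compound 1 to compound 4 (beyond the scatter) means. In this assay compound 4 is expected to give 62%, within a range from 35% to 85%.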

Compound 4, a percentage reported as activity, at one concentration (the size of the read-out at that concentration, not a potency): 58%
For compound 4 the middle estimate is 4 percentage points above the measured one; the range from low to high includes it.
By their numbers in this assay, from the lowest: compounds 3, 2 and 4 (each within the scatter of the next, the first and the last beyond it); then compound 1.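

In this assay, the exchange of fluoro for methoxy, with the group still meta to a large group, gives a number 18 percentage points lower from compound 1 to compound 4 (beyond the scatter). This is the first step shown that changes the group alone and leaves its place alone, so it shows that the identity of the group at this place matters by itself: the earlier steps away from compound 1 could not separate that from a change of place. The same step also shows that this place accepts a group of two heavy atoms carrying a hydrogen-bond acceptor, with compound 4 still giving 58%, although nothing measured here explains the lower number.

Still open, from the compounds shown here alone, is how the number would respond at this same place to a hydroxyl, an amine or a longer chain such as ethoxy, which would show whether the trend continues beyond methoxy. Also open, going by these compounds, is how much of the larger drops on going to compound 2 and compound 3 comes from the change of place and how much from the change of group.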